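Bromo to pentyl exchange on the aryl ring of compound 1

The source may hold more compounds than are shown below. What is called first, only, known or untested is meant among the compounds shown, and "the series" means these compounds.

Measured so far:
- compound 1 `O=C1O[C@H]([C@@H](O)Cn2cc(-c3ccc(Br)cc3)nn2)C(OCc2ccccc2)=C1OCc1ccccc1`: 3910 nM
- compound 2 `O=C1O/C(=C\Cn2cc(-c3cc(F)cc(F)c3)nn2)C(OCc2ccccc2)=C1OCc1ccccc1`: 17700 nM

In a functional assay on HeLa cells (Homo sapiens) for antiproliferative activity, read by MTT assay, with a stated time of 72 h (on this read-out higher numbers stand for weaker inhibition and lower numbers for stronger inhibition), compound 1 holds the lower of the two numbers; compound 2 gives the higher number, and the gap between them lies beyond the scatter. Compound 2 differs from compound 1 in more than one place, so its value says nothing direct about any single change.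

Compound 3 `CCCCCc1ccc(-c2cn(C[C@H](O)[C@H]3OC(=O)C(OCc4ccccc4)=C3OCc3ccccc3)nn2)cc1` is the next compound to be run in this assay. It differs from compound 1 in one place: pentyl in place of bromo on an aromatic carbon. Among the compounds with values here, no measured pair shows this kind of change, so there is no step to lean on. The expected step of a 1.3-fold lower number from compound 1 to compound 3 (0.12 log units; within the scatter) is small, with no firm direction, and is estimated to stay close to the scatter. For compound 3 the estimate in this assay is 3000 nM, with a range from 800 nM to 12000 nM.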

Compound 3, half-maximal inhibitory concentration: 8390 nM
Estimate against measurement, compound 3: 2.8-fold (0.45 log units) below; low and high end bracket the measured number.
By their numbers in this assay, from the lowest: compound 1; then compound 3; then compound 2.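

In this assay, within the data shown here, the exchange of bromo for pentyl gives the first single-place comparison: a 2.1-fold higher number from compound 1 to compound 3 (0.33 log units; beyond the scatter), a modest step. At this aromatic carbon, 4-bromophenyl therefore holds a measurable edge over 4-pentylphenyl, while the pentyl chain still leaves compound 3 with a measurable value in the same assay. No supporting data bear on the origin of this step.

With only one substituent pair at this carbon, the compounds shown cannot separate the loss of bromo from the entry of the pentyl chain. On these data alone, it stays open whether a shorter chain such as propyl, a chlorine or an amine at this carbon would fall nearer compound 1 or compound 3 in this assay and whether the same step would hold on another core.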